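The source may report more compounds than this note shows. Statements on the series, on what has been measured and on what is new or still open speak of the compounds shown alone.

Measured so far:
- Compound 1, `COc1cc(N)c(Cl)cc1C(=O)CCC1CCN(CCNS(=O)(=O)c2cc(Br)ccc2Br)CC1`: 52%
- Compound 2, `COc1ccc(S(=O)(=O)NCCN2CCC(CCC(=O)c3cc(Cl)c(N)cc3OC)CC2)c(OC)c1`: 45%

Both compounds were tested in an assay on HEK293 cells for displacement of a labelled ligand from 5-hydroxytryptamine receptor 6 (Homo sapiens), with a stated time of 60 min, tested at 1 uM, in the presence of a further agent that is not named here; a lower number here means a weaker effect, a higher number a stronger effect of the compound at the concentration tested. Compound 2 shows the lower of the two numbers, with compound 1 sitting a little above it, but the gap between them is within the scatter of repeated measurements, so the two cannot be told apart with confidence. Among the compounds with values here, the only measured step, a number 7 percentage points lower from compound 1 to compound 2 (within the scatter), exchanges one aryl group on the sulfonyl sulfur for another, and it changed the read-out by less than the scatter.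

Compound 3, `COc1cc(N)c(Cl)cc1C(=O)CCC1CCN(CCNS(=O)(=O)c2cc(Br)c(N)c(Br)c2)CC1`, has not yet been measured. It differs from compound 2 at the same position: 4-amino-3,5-dibromophenyl in place of 2,4-dimethoxyphenyl on a sulfonyl sulfur. Within the data shown here, the one measured step at that position bears directly on this change, and it was small. The entering group carries the two bromines also found in compound 1, so a number near that of compound 1 or compound 2 is expected, with no step beyond the scatter: the estimated step is a number 5 percentage points higher from compound 2 to compound 3 (within the scatter). Compound 3 is therefore expected to give about 50%, in a range from 30% to 70%.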

Compound 3, a percentage reported as inhibition, at one concentration (the size of the read-out at that concentration, not a potency): 83%
Compound 3: middle estimate off by 33 percentage points, on the low side; the measured number lies above the stated range.
By their numbers in this assay, from the lowest: compounds 2 and 1 (each within the scatter of the next); then compound 3.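

The aryl group on the sulfonyl sulfur is not as forgiving as the first exchange there suggested: in this assay, 4-amino-3,5-dibromophenyl gives a number 38 percentage points higher from compound 2 to compound 3 (beyond the scatter), and it also gives a number 31 percentage points higher from compound 1 to compound 3 (beyond the scatter), whereas the earlier exchange gave only a number 7 percentage points lower from compound 1 to compound 2 (within the scatter). The second of these large steps shows that two bromines on the ring are not enough for the higher number, since the 2,5-dibromophenyl of compound 1 also has two and stays well short of compound 3. Nothing shown here accounts for the rise, so the structures record only that it happened, not why.

The entering group brings an amino group and a different bromine arrangement in a single change, so these compounds cannot say which of them matters, or whether both are needed; a phenyl carrying only the amino group, or one with chlorine in place of each bromine, would help to separate them. Going by these compounds, each number also comes from a single concentration, so how much potency lies behind the higher read-out of compound 3 remains open.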